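A few compounds are considered here, and "the series" means these few. Any claim that something is new, unique, unknown or untested is made for them only; others in the source may bear on it.

Measured so far:
compound 1 `CCC(C(=O)N[C@@H](CC(=O)O)C(=O)CNCN1CCCCC1)n1cc(C(C)(C)C)nc(NCc2nonc2C)c1=O` — 0.29 nM
compound 2 `CCC(C(=O)N[C@@H](CC(=O)O)C(=O)CSCc1ccccc1)n1ccnc(NCc2nc(C)no2)c1=O` — 5.33 nM

Both compounds were run in a functional assay on NT2 cells (Homo sapiens) for inhibition; on this read-out higher numbers stand for weaker inhibition and lower numbers for stronger inhibition. Compound 1 gives 0.29 nM and compound 2 gives 5.33 nM. Of the two numbers, compound 2 carries the higher one, and its gap to compound 1 lies beyond the scatter. The two structures differ in several places at once, so that gap cannot be tied to any single change.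

Compound 3 `CCC(C(=O)N[C@@H](CC(=O)O)C(=O)CSCc1ccccc1)n1ccnc(NCCCOC)c1=O` is not yet measured in this assay. It differs from compound 2 in one place: 2-methoxyethyl in place of 3-methyl-1,2,4-oxadiazol-5-yl on a saturated chain carbon bound to a nitrogen on an aromatic ring. The group that leaves carries one five-membered aromatic ring with three hetero atoms; what enters has no ring.

Among the compounds with values here, no measured pair isolates this change, so the expectation rests on compound 2 alone. The step from compound 2 to compound 3 is expected to run toward a higher number in this assay by a 2.8-fold higher number from compound 2 to compound 3 (0.45 log units; beyond the scatter), a shift that should exceed the scatter without being large. Compound 3 is estimated at 15 nM, with a range from 4 nM to 60 nM.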

Compound 3, half-maximal inhibitory concentration: > 10 nM
Compound 3: a limit, no number; the forecaster's own chance of this, stated with the estimate: 2%; the middle value lies beyond the limit too.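

Compound 3 carries only a limit, not a number, in this assay: the limit of > 10 nM in this assay, at which 1 of the 3 values shown sits. Within the data shown here, its change gives the only single-place step, with 2-methoxyethyl in place of 3-methyl-1,2,4-oxadiazol-5-yl on a saturated chain carbon bound to a nitrogen on an aromatic ring, and that step reads as an at least 1.8-fold higher number from compound 2 to compound 3 (0.27 log units; that floor lies within the scatter). This position therefore accepts the ring-free chain without any gain in inhibition over compound 2, but the floor of the step does not establish a loss beyond the scatter, and the true size of the change remains unfixed.

With a single step at this position, the data cannot separate the loss of the five-membered aromatic ring from the loss of its hetero atoms, and no cause can be assigned to the result. Going by these compounds, how a phenyl ring or a chain ending in an amine or a carboxylic acid would read in this place stays open, as does the share of this position in the gap between compound 1 and compound 2, whose structures differ in several places.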